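Swapping the para halogen on the imine aryl ring

A few compounds are considered here, and "the series" means these few. Any claim that something is new, unique, unknown or untested is made for them only; others in the source may bear on it.

Measured compounds:
Compound 1, `CCCCc1oc2ccc(/N=C/c3ccc(C#N)cc3)cc2c1C(=O)c1ccc(OC)cc1`, gives 27.2 ug/mL.
Compound 2, `CCCCc1oc2ccc(/N=C/c3cccc([N+](=O)[O-])c3)cc2c1C(=O)c1ccc(OC)cc1`, gives 34.2 ug/mL.
Compound 3, `CCCCc1oc2ccc(/N=C/c3ccc(Cl)cc3)cc2c1C(=O)c1ccc(OC)cc1`, gives 75.9 ug/mL.

All three were tested in a functional assay, with a stated time of 30 min; a higher number here means a weaker inhibitor, a lower number a stronger inhibitor. Compound 3 stands at the highest of the three numbers; the step of a 2.8-fold higher number from compound 1 to compound 3 (0.45 log units; beyond the scatter) and the step of a 2.2-fold higher number from compound 2 to compound 3 (0.35 log units; beyond the scatter) both lie beyond the scatter, while compound 1 and compound 2 sit within the scatter of each other, as the step of a 1.3-fold higher number from compound 1 to compound 2 (0.10 log units; within the scatter) shows.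

Compound 4, `CCCCc1oc2ccc(/N=C/c3ccc(F)cc3)cc2c1C(=O)c1ccc(OC)cc1`, has not yet been measured. It differs from compound 3 by fluoro in place of chloro on an aromatic carbon. Within the data shown here, no measured step in this set exchanges one halogen for another; the only change at this position that is known is the step of a 2.8-fold higher number from compound 1 to compound 3 (0.45 log units; beyond the scatter), where cyano gave way to chloro. That step tells how much this position can move the number, but not which way a fluoro would go. Compound 4 is therefore expected to give a number near that of compound 3, with no step beyond the scatter as the likeliest outcome, a 1.3-fold lower number from compound 3 to compound 4 (0.10 log units; within the scatter). The estimate for compound 4 in this assay is 60 ug/mL, with a range from 25 ug/mL to 150 ug/mL.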

Compound 4, half-maximal inhibitory concentration: 100 ug/mL
Compound 4: the middle estimate sits 1.7-fold (0.22 log units) below what was measured; measured number inside the range.
By their numbers in this assay, from the lowest: compounds 1 and 2 (each within the scatter of the next); then compounds 3 and 4 (each within the scatter of the next).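

With fluoro in place of chloro on this aromatic carbon, this assay gives the step of a 1.3-fold higher number from compound 3 to compound 4 (0.12 log units; within the scatter) and so does not tell the two halogens apart. The separation first seen with chloro now holds for a second halogen, with a 3.7-fold higher number from compound 1 to compound 4 (0.57 log units; beyond the scatter) and a 2.9-fold higher number from compound 2 to compound 4 (0.47 log units; beyond the scatter) placing the 4-fluorophenyl compound on the weaker side of both the cyano and the 3-nitrophenyl compounds. No measurement is at hand that would explain this grouping.

On these data alone, it remains open whether bromo, or a group of a different kind such as an amine or a carboxylic acid, would stay with the two halogens or join compound 1 and compound 2. The compounds shown also leave open whether the same grouping would hold with a different substituent elsewhere on the shared core.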